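The source may hold more compounds than are shown below. What is called first, only, known or untested is meant among the compounds shown, and "the series" means these compounds.

Compounds measured in a functional assay on MDA-MB-231 cells (Homo sapiens) for cytotoxicity, read by MTT assay, with a stated time of 72 h; on this read-out lower numbers stand for stronger inhibition and higher numbers for weaker inhibition:
compound 1 `COc1cc2c(Oc3ccc(NC(=O)c4nn(-c5ccccc5F)c(=O)c5ccccc45)cc3F)ccnc2cc1OCCCN1CCCC1`: 950 nM
compound 2 `COc1cc2c(Oc3ccc(NC(=O)c4nn(-c5ccccc5Br)c(=O)c5ccccc45)cc3F)ccnc2cc1OCCCN1CCCC1`: 1020 nM
compound 3 `COc1cc2c(Oc3ccc(NC(=O)c4nn(-c5ccc([N+](=O)[O-])cc5)c(=O)c5ccccc45)cc3F)ccnc2cc1OCCCN1CCCC1`: 2980 nM

Compound 3 gives the highest number of the three in this assay. Its steps to the two others are both beyond the scatter: a 3.1-fold higher number from compound 1 to compound 3 (0.50 log units; beyond the scatter) and a 2.9-fold higher number from compound 2 to compound 3 (0.47 log units; beyond the scatter). Compounds 1 and 2 lie within the scatter of each other (a 1.1-fold higher number from compound 1 to compound 2 (0.03 log units; within the scatter)).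

Compound 4 `COc1ccc(-n2nc(C(=O)Nc3ccc(Oc4ccnc5cc(OCCCN6CCCC6)c(OC)cc45)c(F)c3)c3ccccc3c2=O)cc1` is not yet measured. It differs from compound 3 in one place: methoxy in place of nitro on an aromatic carbon. The measured steps that bear on it are the two leading into compound 3, in which 4-nitrophenyl replaced an ortho-halophenyl and the number rose modestly. Going by the values given here, no measured step exchanges one group for another at the same position of the 4-substituted phenyl, so the direction of the nitro-to-methoxy change is not covered directly. The expectation is therefore uncertain: a step in either direction within or modestly beyond the scatter is plausible, with a slight lean toward a lower number, back toward compounds 1 and 2. For compound 4 the estimated step is a 1.5-fold lower number from compound 3 to compound 4 (0.17 log units; within the scatter). Compound 4 is thus expected to give about 2000 nM in this assay, with a range from 800 nM to 5000 nM.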

Compound 4, half-maximal inhibitory concentration: 3450 nM
The estimate for compound 4 lay 1.7-fold (0.24 log units) below the measured number, and the stated range covers the measured number.
By their numbers in this assay, from the lowest: compounds 1 and 2 (each within the scatter of the next); then compounds 3 and 4 (each within the scatter of the next).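

Working notes: in this assay, the exchange at the aromatic carbon para to a large group gives the first direct comparison at this position (a 1.2-fold higher number from compound 3 to compound 4 (0.06 log units; within the scatter)), and the step lies within the scatter, so nitro and methoxy are not told apart here. The modest gap to the halogen-bearing compounds also recurs with methoxy (a 3.4-fold higher number from compound 2 to compound 4 (0.53 log units; beyond the scatter); a 3.6-fold higher number from compound 1 to compound 4 (0.56 log units; beyond the scatter)), so it is not confined to the 4-nitrophenyl compound. No accompanying measurement bears on why these numbers fall as they do.

Compounds 1 and 2 differ from compounds 3 and 4 both in the group on the phenyl and in where it sits, and the compounds shown do not separate these two changes. On these data alone, whether an amine or a carboxylic acid on the same aromatic carbon would give a number outside the scatter of compounds 3 and 4 also remains open.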